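Swapping the aryl group on the carbonyl of compound 1

This account rests on a few compounds, and the source may have more. Where it says the series, first, only, none or still open, it means among the compounds named here.

Compound 1 `COc1ccc(-c2cc3ccccc3nc2/C=C/C(=O)c2ccc(OC)c(OC)c2)cc1` carries a 3,4-dimethoxyphenyl group on its carbonyl carbon. In a functional assay on H184B5F5/M10 cells (Homo sapiens) for antiproliferative activity, read by XTT assay, with a stated time of 72 h (a higher number here means a weaker inhibitor, a lower number a stronger inhibitor), compound 1 gives 7240 nM. Among the three measured numbers, compound 1 sits second highest, but its gaps to compound 3 and to compound 2 both lie within the scatter. Compound 2 `COc1ccc(-c2cc3ccccc3nc2/C=C/C(=O)c2ccc(N)cc2)cc1` gives 9290 nM, and compound 3 `COc1ccc(-c2cc3ccccc3nc2/C=C/C(=O)c2ccc([N+](=O)[O-])cc2)cc1` gives 6100 nM. The two steps that start from compound 1 both exchange the aryl group on the carbonyl carbon: a 1.3-fold higher number from compound 1 to compound 2 (0.11 log units; within the scatter) and a 1.2-fold lower number from compound 1 to compound 3 (0.07 log units; within the scatter). Between the two amended compounds, a 1.5-fold lower number from compound 2 to compound 3 (0.18 log units; within the scatter).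

Compound 4 `COc1ccc(-c2cc3ccccc3nc2/C=C/C(=O)c2ccsc2)cc1` differs from compound 1 in one place: thiophen-3-yl in place of 3,4-dimethoxyphenyl on a carbonyl carbon. The steps from compound 1 to compound 2 and to compound 3 bear directly on this change, since each also replaced the aryl group on the carbonyl carbon, and neither moved the number beyond the scatter. The expectation for compound 4 is therefore a step of a 1.0-fold lower number from compound 1 to compound 4 (0.01 log units; within the scatter), with no clear direction. Compound 4 is estimated at 7000 nM, with a range from 2500 nM to 20000 nM.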

Compound 4, half-maximal inhibitory concentration: 6390 nM
For compound 4 the middle estimate is 1.1-fold (0.04 log units) above the measured one, within the range that was stated.
By their numbers in this assay, from the lowest: compounds 3, 4, 1 and 2 (each within the scatter of the next).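

The earlier swaps on the carbonyl carbon exchanged one substituted phenyl group for another, whereas thiophen-3-yl brings a five-membered aromatic ring with 1 hetero atom, yet the number hardly responds (a 1.1-fold lower number from compound 1 to compound 4 (0.05 log units; within the scatter)). Set against the other two aryl groups, the result is the same, with a 1.0-fold higher number from compound 3 to compound 4 (0.02 log units; within the scatter) and with a 1.5-fold lower number from compound 2 to compound 4 (0.16 log units; within the scatter) both staying within the scatter, so even a change of ring size leaves all four compounds indistinguishable at this place. No measurement is available that could explain this insensitivity.

From the compounds shown here alone, all four groups on the carbonyl carbon are aromatic rings, so what a non-aromatic group such as cyclohexyl or a plain methyl would do here remains open. Also open, going by these compounds, is whether any group at this place can move the number beyond the scatter.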